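Swapping a Methylphenyl for Dichlorophenyl on a Sulfonamide

This account rests on a few compounds, and the source may have more. Where it says the series, first, only, none or still open, it means among the compounds named here.

Measured compounds:
compound 1, `Cc1cccc(S(=O)(=O)N2CCC(N3CCC(C)CC3)CC2)c1`, > 5000 nM
compound 2, `Cc1ccc(C#N)c(S(=O)(=O)N2CCC(N3CCC(C)CC3)CC2)c1`, > 5000 nM
compound 3, `Cc1ccc(-c2cccc(S(=O)(=O)N3CCC(N4CCC(C)CC4)CC3)c2)cc1`, > 5000 nM

In an ADME assay on HCT-116 cells (Homo sapiens) for cytotoxicity, read by CellTiter-Glo, with a stated time of 72 h (a higher number here means a weaker inhibitor, a lower number a stronger inhibitor), compound 1 gives only a limit of the assay, > 5000 nM. Compound 2 likewise reaches only a limit, > 5000 nM. Compound 3 as well stops at a limit, > 5000 nM. Because of the limit of > 5000 nM in this assay, at which 3 of the 3 values shown sit, the two measured steps, a step that the two limits leave unreadable from compound 1 to compound 2 and a step that the two limits leave unreadable from compound 1 to compound 3, have no readable size: both ends of each step sit at the same limit, so the change on the aromatic ring of the sulfonyl group cannot be seen to help or hurt in this assay.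

Compound 4, `CC1CCN(C2CCN(S(=O)(=O)c3ccc(Cl)cc3Cl)CC2)CC1`, differs from compound 1 by 2,4-dichlorophenyl in place of 3-methylphenyl on a sulfonyl sulfur. Both measured steps alter the same aromatic ring, so they are the ones that bear on this change, yet neither can be sized. With every measured value resting at the limit, no direction beyond the scatter can be predicted, and compound 4 is expected to stay at the limit too. Compound 4 is therefore estimated at 8000 nM, within a range of 4000 nM to 20000 nM. This corresponds to an expected step that the limit leaves unreadable from compound 1 to compound 4.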

Compound 4, half-maximal inhibitory concentration: > 5000 nM
Compound 4 ended at the assay's limit; the forecaster's own chance of this, stated with the estimate: 85%; the middle value lies beyond the limit too.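

Compound 4 adds no step of readable size from compound 1, because both compounds stop at the same limit: the limit of > 5000 nM in this assay, at which 4 of the 4 values shown sit.

Which change to the aromatic ring on the sulfonyl sulfur, if any, would give a measurable value in this assay remains open.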